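Acyl variation on the shared core of compound 2

The source may report more compounds than this note shows. Statements on the series, on what has been measured and on what is new or still open speak of the compounds shown alone.

Compound 1 `CCN1CCc2nc(C#Cc3ccccc3)sc2C1` in an assay on HEK293 cells for positive allosteric modulation of metabotropic glutamate receptor 5 (Homo sapiens), read by FLIPR, with a stated time of 1 h (a higher number here means that more compound is needed for the effect, a lower number that less compound is needed), gives only a limit of the assay, > 10000 nM. Compound 2 `CCC(=O)N1CCc2nc(C#Cc3ccccc3)sc2C1` in this assay likewise gives only a limit, > 10000 nM. The step that the two limits leave unreadable from compound 1 to compound 2 cannot be read because both values sit at the limit of > 10000 nM in this assay, at which 2 of the 2 values shown sit. Compound 2 therefore stands at the limit, with no number of its own. Compound 3 `CC1CC1C(=O)N1CCc2nc(C#Cc3ccccc3)sc2C1` differs from compound 2 by 2-methylcyclopropyl in place of ethyl on a carbonyl carbon. Within the data shown here, no measured step bears on this change; the only step in hand is unreadable. No movement beyond the scatter is expected for the step of a number no higher from compound 2 to compound 3 (the limit leaves the size open). Compound 3 is expected near 10000 nM, within 3000 nM to 30000 nM, most likely again reported as a limit.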

Compound 3, half-maximal effective concentration: 9.4 nM
Compound 3: the middle estimate sits 1100-fold (3.03 log units) above what was measured, outside the stated range (below it).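

At this carbonyl carbon, 2-methylcyclopropyl in place of ethyl gives the series its first readable number in this assay, with an at least 1000-fold lower number from compound 2 to compound 3 (3.02 log units; beyond the scatter). The wider change, (2-methylcyclopropyl)carbonyl in place of ethyl on the amine nitrogen in a ring, gives an at least 1000-fold lower number from compound 1 to compound 3 (3.02 log units; beyond the scatter). The step between the two earlier compounds cannot be read: the limit of > 10000 nM in this assay, at which 2 of the 3 values shown sit.

Open, as far as these compounds go, is whether the ring or its methyl carries the step, a question for plain cyclopropyl on the same carbonyl. Also open, from the compounds shown here alone, is how a longer chain such as butanoyl would read there.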